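Removing the (5-hydroxypentyl)carbamoyl group from compound 1

A few compounds are considered here, and "the series" means these few. Any claim that something is new, unique, unknown or untested is made for them only; others in the source may bear on it.

Compound 1 (`COc1cc(NC(C)CCCNC(=O)NNC(=O)NCCCCCO)c2ncccc2c1`) gives > 100000 nM
Compound 2 (`COc1ccc(C(=NNC(=O)NNC(=O)NCCCC(C)Nc2cc(OC)cc3cccnc23)c2ccc(OC)cc2)cc1`) gives 5000 nM
Compound 3 (`COc1cc(NC(C)CCCNC(=O)NNC(=O)Nc2ccc(Cl)c(C(F)(F)F)c2)c2ncccc2c1`) gives 13000 nM

All three were read in a functional assay on NCI-H460 cells (Homo sapiens) for inhibition, read by MTT assay, with a stated time of 4 days (a lower number here means a stronger inhibitor, a higher number a weaker inhibitor), as a half-maximal inhibitory concentration. Compound 1 stands at the limit of > 100000 nM in this assay, at which 1 of the 3 values shown sits, and this entry is a limit of the assay, not a number.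

Compound 4 (`COc1cc(NC(C)CCCNC(=O)NN)c2ncccc2c1`) has not yet been measured. It is compound 1 with hydrogen in place of (5-hydroxypentyl)carbamoyl on an amine nitrogen.

One measured step changes the same end of compound 1. Putting 4-chloro-3-(trifluoromethyl)phenyl in place of 5-hydroxypentyl on an amide-type nitrogen gave an at least 7.6-fold lower number from compound 1 to compound 3 (0.88 log units; beyond the scatter) as its result. Compound 2, which carries a different end again, gives 5000 nM in the same test. That step swaps one group for another, whereas compound 4 simply loses the group, so it is only a loose guide. Within the data shown here, no measured step shows a plain removal. Taking the direction alone, the expected change is an at least 2.5-fold lower number from compound 1 to compound 4 (0.39 log units; beyond the scatter) in this assay as a modest estimate. A reading that gives only a limit remains possible. For compound 4 the estimated value is 40000 nM with an expected range from 10000 nM to 100000 nM in this estimate.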

Compound 4, half-maximal inhibitory concentration: > 100000 nM
Compound 4 ended at the assay's limit; the forecaster's own chance of this, stated with the estimate: 35%; middle value at least 2.5-fold (0.39 log units) from the limit.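

In this assay compound 4 gives > 100000 nM as a limit of the assay and not a number. Among these compounds, compound 1 also stands at a limit, so no step from compound 1 to compound 4 can be read: the limit of > 100000 nM in this assay, at which 2 of the 4 values shown sit. The compounds shown leave open whether losing the (5-hydroxypentyl)carbamoyl group changes the result at all.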